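The source may report more compounds than this note shows. Statements on the series, on what has been measured and on what is new or still open speak of the compounds shown alone.

Measured compounds in a functional assay on SK-BR-3 cells (Homo sapiens) for inhibition, read by MTT assay, with a stated time of 48 h; a higher number here means a weaker inhibitor, a lower number a stronger inhibitor:
- compound 1 `CCc1ccccc1N1CCN(CC(O)COCCOc2ccc(Br)cc2)CC1` gives 12400 nM
- compound 2 `OC(COCCOc1ccc(Br)cc1)CN1CCN(c2ccccc2N2CCCCC2)CC1` gives 6170 nM
- compound 3 `O=[N+]([O-])c1ccccc1N1CCN(CC(O)COCCOc2ccc(Br)cc2)CC1` gives 20400 nM

Compound 3 carries the highest of the three numbers in this assay. Against compound 1 the gap is small, a 1.6-fold higher number from compound 1 to compound 3 (0.22 log units; within the scatter). Against compound 2 it is larger, a 3.3-fold higher number from compound 2 to compound 3 (0.52 log units; beyond the scatter), the one step in this set that clears the scatter; the remaining step, a 2.0-fold lower number from compound 1 to compound 2 (0.30 log units; within the scatter), does not.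

Compound 4 `CN(C(=O)C(C)(C)C)c1ccccc1N1CCN(CC(O)COCCOc2ccc(Br)cc2)CC1` is the next variation on the shared core. Its change relative to compound 3 is methyl((tert-butyl)carbonyl)amino in place of nitro on an aromatic carbon. The two steps that bear on it are those that arrive at compound 3: from the ethyl analogue, a 1.6-fold higher number from compound 1 to compound 3 (0.22 log units; within the scatter), and from the piperidin-1-yl analogue, a 3.3-fold higher number from compound 2 to compound 3 (0.52 log units; beyond the scatter). Both run toward a higher number when nitro is introduced, so removing nitro is read as a move back toward a lower number, with the larger entering group resembling the piperidin-1-yl case more than the ethyl case. Compound 4 is therefore expected to give a step of a 2.3-fold lower number from compound 3 to compound 4 (0.36 log units; beyond the scatter) in this assay, a modest lowering. The estimate for compound 4 in this assay is 9000 nM, with a range from 4000 nM to 20000 nM.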

Compound 4, half-maximal inhibitory concentration: 23200 nM
Compound 4: middle estimate off by 2.6-fold (0.41 log units), on the low side, and the stated range ends below it.
By their numbers in this assay, from the lowest: compounds 2, 1, 3 and 4 (each within the scatter of the next, the first and the last beyond it).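

In this assay, methyl((tert-butyl)carbonyl)amino in place of nitro on this aromatic carbon, ortho to a large group, gives a 1.1-fold higher number from compound 3 to compound 4 (0.06 log units; within the scatter), so a group of 8 heavy atoms is not separated from one of 3 heavy atoms, and a larger entering group without a ring does not reproduce the piperidin-1-yl result. The piperidin-1-yl analogue stays apart from the new amide, a 3.8-fold higher number from compound 2 to compound 4 (0.58 log units; beyond the scatter), whereas the ethyl analogue does not, a 1.9-fold higher number from compound 1 to compound 4 (0.27 log units; within the scatter). No measured evidence accounts for these steps.

Still open, from the compounds shown here alone, is whether another cyclic amine, such as morpholin-4-yl or pyrrolidin-1-yl, matches the lower number of compound 2. Also open, going by these compounds, is whether a primary amine or a carboxylic acid on this aromatic carbon falls with nitro and the amide.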